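The source may report more compounds than this note shows. Statements on the series, on what has been measured and on what is new or still open speak of the compounds shown alone.

Measured so far:
Compound 1, `O=C(O)CCCc1cn(CC(=O)O)c2c(/C=C/c3ccc(OCCCCc4c(F)ccc(F)c4F)cc3)cccc12` — 1 nM
Compound 2, `Cc1c(Cl)cccc1CCCCOc1ccc(C#Cc2cccc3c(CC(=O)O)c(C)n(CCCCC(=O)O)c23)cc1` — 65 nM

The two measured compounds were tested in a functional assay on CHO-K1 cells for antagonist activity at cysteinyl leukotriene receptor 1 (Homo sapiens), read by fluorescence and calcium flux, with stated times of 30 min and 1 h; a higher number here means a weaker inhibitor, a lower number a stronger inhibitor. Compound 1 gives 1 nM, the lower of the two numbers, while compound 2 gives 65 nM, and the gap between them lies beyond the scatter of the method. Compound 1 is therefore the stronger inhibitor of the pair.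

Compound 3, `O=C(O)CCCc1cn(CC(=O)O)c2c(/C=C/c3ccc(OCCCCOc4ccccc4)cc3)cccc12`, has not yet been measured in this assay. It is derived from compound 1 by a single change: phenoxy in place of 2,3,6-trifluorophenyl on a saturated chain carbon, four bonds along the chain from an oxygen on an aromatic ring. Among the measured compounds shown here, no comparable step between measured compounds exists to guide the reading, so the outcome rests on compound 1 alone. A modest weakening is expected, with the step from compound 1 to compound 3 estimated at a 3.0-fold higher number from compound 1 to compound 3 (0.48 log units; beyond the scatter). Compound 3 is accordingly expected to give about 3 nM, within a range of 1 nM to 15 nM.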

Compound 3, half-maximal inhibitory concentration: 1.5 nM
Beside the measured number, compound 3's estimate is 2.0-fold (0.30 log units) above it; the range from low to high includes it.
By their numbers in this assay, from the lowest: compounds 1 and 3 (each within the scatter of the next); then compound 2.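

In this assay, putting phenoxy in place of 2,3,6-trifluorophenyl on a saturated chain carbon, four bonds along the chain from an oxygen on an aromatic ring, gives a 1.5-fold higher number from compound 1 to compound 3 (0.18 log units; within the scatter). This position therefore accepts the exchange with no step beyond the scatter, and the fluorine atoms of compound 1 are not needed for a number this low, since compound 3 carries none and brings one hydrogen-bond acceptor in the entering group. No measurement at hand speaks to what lies behind this result.

The compounds shown do not tell how an unsubstituted phenyl, a 2,3,6-trifluorophenoxy group or an amine would read at this position. They also leave open whether a longer chain carrying phenoxy would keep the number in the same range.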